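The source may report more compounds than this note shows. Statements on the series, on what has been measured and on what is new or still open speak of the compounds shown alone.

Measured so far in an in vitro ADME assay on microsomes from liver (Homo sapiens) for pharmacokinetics, read by LC-MS; on this read-out higher numbers stand for fast clearance and lower numbers for slow clearance:
- compound 1 `Cc1cccc2c1nc(C)n2-c1ccc(C(=O)NC2CC2)s1`: 10 mL/min/kg
- compound 2 `Cc1nc2c(Cl)cccc2n1-c1ccc(C(=O)NC2CC2)s1`: < 4 mL/min/kg (a limit, not a number)

Compound 2 gives no exact number and sits at the limit of < 4 mL/min/kg in this assay, at which 1 of the 2 values shown sits. Compound 3 `Cc1nc2c(C#N)cccc2n1-c1ccc(C(=O)NC2CC2)s1` has not been measured in this assay. It carries cyano in place of chloro on an aromatic carbon.

Among the compounds with values here, the one measured step that bears on this change also swaps the group on an aromatic carbon. That step, with chloro in place of methyl, is an at least 2.5-fold lower number from compound 1 to compound 2 (0.39 log units; beyond the scatter). Within the data shown here, it covers only methyl and chloro, and no measured step involves cyano. Its size therefore cannot simply be carried over to the new change, and it gives no firm direction. No step beyond the scatter is expected in this assay, although a small rise would not be surprising.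

The expected change is a number no lower from compound 2 to compound 3 (the limit leaves the size open). For compound 3 the estimated clearance is 4 mL/min/kg, with an expected range from 2 mL/min/kg to 8 mL/min/kg.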

Compound 3, clearance: < 4 mL/min/kg
Compound 3 gave a limit, no number; the forecaster's own chance of this, stated with the estimate: 55%; the middle value sits exactly at the limit.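

In this assay, cyano on this aromatic carbon gives a clear drop against methyl, with an at least 2.5-fold lower number from compound 1 to compound 3 (0.39 log units; beyond the scatter). The earlier at least 2.5-fold lower number from compound 1 to compound 2 (0.39 log units; beyond the scatter) covered chloro alone, so a single replacement could have been a special case; on this carbon, ortho to a fused ring and meta to a fused ring, two different groups in place of methyl now each give a step beyond the scatter. The step between chloro and cyano cannot be read, and neither group can be ranked over the other, because compound 2 and compound 3 both end at the floor of the read-out rather than at numbers: the limit of < 4 mL/min/kg in this assay, at which 2 of the 3 values shown sit.

The compounds shown hold only methyl, chloro and cyano at this position, so it stays open whether a methoxy group or an amine there would also match the result for compound 2 and compound 3. Also open, as far as these compounds go, is how far under the limit compound 2 and compound 3 really lie, and whether the same replacements would hold with another group in place of the cyclopropyl on the amide.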